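This account rests on a few compounds, and the source may have more. Where it says the series, first, only, none or still open, it means among the compounds named here.

In an ADME assay on microsomes from liver (Rattus norvegicus) for metabolic stability, read by LC-MS, in the presence of a further agent that is not named here (on this read-out higher numbers stand for fast clearance and lower numbers for slow clearance), compound 1 `Cc1ncc(C)n2nc(-c3ccn4cc(-c5ccc(F)cc5Cl)nc4n3)nc12` gives 11.5 mL.min-1.g-1 and compound 2 `Cc1ncc(C)n2nc(-c3ccc4nc(-c5ccccn5)[nH]c4c3)nc12` gives 11.1 mL.min-1.g-1, two values within the usual scatter of each other. Compound 3 `Cc1nc(-c2ccc3nc(-c4ccccc4)[nH]c3c2)nc2ccccc12` stands apart: its > 450 mL.min-1.g-1 is a limit of this assay, not a number. Compound 4 `Cc1ncc(C)n2nc(-c3ccn4cc(-c5cccc(Cl)c5)nc4n3)nc12` keeps the core of compound 1 but carries 3-chlorophenyl in place of 2-chloro-4-fluorophenyl on an aromatic carbon. Among the compounds with values here, no measured pair here isolates a swap of this kind, so the starting point is compound 1 at 11.5 mL.min-1.g-1. The expected change, a 1.7-fold higher number from compound 1 to compound 4 (0.24 log units; within the scatter), is small and leans slightly toward faster clearance. For compound 4 the estimated intrinsic clearance is 20 mL.min-1.g-1, with an expected range of 8 mL.min-1.g-1 to 55 mL.min-1.g-1.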

Compound 4, intrinsic clearance in microsomes: 18.9 mL.min-1.g-1
Estimate against measurement, compound 4: 1.1-fold (0.02 log units) above; the measured number falls inside the stated range.
By their numbers in this assay, from the lowest: compounds 2, 1 and 4 (each within the scatter of the next). At a limit, above all of these: compound 3.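

Within the data shown here, this is the one step at this position that can be read: in this assay, 3-chlorophenyl in place of 2-chloro-4-fluorophenyl gives a 1.6-fold higher number from compound 1 to compound 4 (0.22 log units; within the scatter), so on the core of compound 1 this swap leaves clearance within the scatter. The swap removes the fluorine and places the chlorine elsewhere on the phenyl ring, and the step cannot separate these two changes. Nothing measured here bears on the reason for this result. As far as these compounds go, it remains open whether a group other than a substituted phenyl at this place, such as an amine or a carboxylic acid, would shift clearance beyond the scatter. From the compounds shown here alone, the separate contributions of the fluorine and the chlorine also remain open.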